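Replacing Isopropoxy by Methylsulfanyl on the Aryl Amide

The source may report more compounds than this note shows. Statements on the series, on what has been measured and on what is new or still open speak of the compounds shown alone.

Measured compounds:
compound 1, `CC(C)Oc1cccc(NC(=O)CN2CCC(c3cccc[n+]3[O-])CC2)c1`, 555 nM
compound 2, `Cc1cccc(C(=O)NCN2CCC(c3cccc[n+]3[O-])CC2)c1`, 89 nM
compound 3, `Cc1cccc(NC(=O)CN2CCC(c3ccccc3C)CC2)c1`, 340 nM

Of the compounds shown here, three have been tested in a functional assay on HEK293 cells for agonist activity at D(4) dopamine receptor (Homo sapiens), read by FLIPR; a lower number here means that less compound is needed, a higher number that more compound is needed for the effect. Compound 1 gives 555 nM, the highest of the three numbers. Its nearest neighbour is compound 3 with 340 nM, a gap that lies within the usual scatter, so the two cannot be ordered. Compound 2 with 89 nM lies furthest away, beyond the scatter, and thus needs clearly less compound than compound 1. Among the compounds with values here, compounds 2 and 3 each differ from compound 1 in more than one place, so no single step between measured compounds is available.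

The next compound, compound 4, `CSc1cccc(NC(=O)CN2CCC(c3cccc[n+]3[O-])CC2)c1`, differs from compound 1 in one place: methylsulfanyl in place of isopropoxy on an aromatic carbon. Within the data shown here, the change is a swap of one substituent for another, and nothing among the measured compounds isolates the effect of such a swap on the aryl amide. Among the measured compounds shown here, with no step to lean on, the expectation is a small step, none beyond the scatter, and the estimated step of a 1.4-fold lower number from compound 1 to compound 4 (0.14 log units; within the scatter) is placed at only a slight decrease. Compound 4 is therefore expected to give about 400 nM, within a range from 130 nM to 1200 nM.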

Compound 4, half-maximal effective concentration: 100 nM
Beside the measured number, compound 4's estimate is 4.0-fold (0.60 log units) above it; measured number below the stated range.
By their numbers in this assay, from the lowest: compounds 2 and 4 (each within the scatter of the next); then compounds 3 and 1 (each within the scatter of the next).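

In this assay, the swap of isopropoxy for methylsulfanyl on the aromatic carbon, meta to a large group, gives a 5.6-fold lower number from compound 1 to compound 4 (0.74 log units; beyond the scatter), a step beyond the scatter. Within the data shown here, the earlier compounds each differed from one another in more than one place, so this is the first step showing that a change in this substituent alone, with the rest of the core of compound 1 held constant, can shift the number clearly. The group leaving has 4 heavy atoms and the one entering has 2, with oxygen replaced by sulfur and 1 hydrogen-bond acceptor on each, and the data offer no measurement that accounts for the size of the step.

The compounds shown leave open whether the step follows the sulfur or the smaller group: methoxy would keep the oxygen with a single carbon, while isopropylsulfanyl would keep the sulfur with the larger branched chain. Also open, as far as these compounds go, is how this position would respond to an amine or a carboxylic acid in place of either group.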